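This account rests on a few compounds, and the source may have more. Where it says the series, first, only, none or still open, it means among the compounds named here.

Compound 3 `COc1ccc(C(=O)N2CCC(n3cncc3-c3ccc(OS(=O)(=O)c4cccc5cnccc45)cc3)CC2)cc1` stands lowest of the three numbers measured in an assay on HEK293 cells for antagonist activity at P2X purinoceptor 7 (Homo sapiens), read by fluorescence, with a stated time of 2 h (on this read-out lower numbers stand for stronger inhibition and higher numbers for weaker inhibition), giving 77 nM in this assay. Among the measured compounds shown here, compound 1 `O=C(c1ccc(Cl)c(C(F)(F)F)c1)N1CCC(n2cncc2-c2ccc(OS(=O)(=O)c3ccccc3)cc2)CC1` gives 702 nM in this assay and compound 2 `O=C(c1ccc(Cl)c(C(F)(F)F)c1)N1CCC(n2cncc2-c2ccc(OS(=O)(=O)c3cccc4ccccc34)cc2)CC1` gives 3520 nM in this assay; the single measured step, a 5.0-fold higher number from compound 1 to compound 2 (0.70 log units; beyond the scatter), is naphthalen-1-yl in place of phenyl on a sulfonyl sulfur. Compound 4 `N#Cc1ccc(C(=O)N2CCC(n3cncc3-c3ccc(OS(=O)(=O)c4cccc5cnccc45)cc3)CC2)cc1` differs from compound 3 elsewhere: cyano in place of methoxy on an aromatic carbon. For the measured compounds named here, no measured pair shows cyano in place of methoxy on an aromatic carbon, so the measured step does not bear on this change, and the three compounds point in no direction for it. Compound 4 is therefore expected to show a 1.0-fold higher number from compound 3 to compound 4 (0.02 log units; within the scatter), nothing beyond the scatter, with an estimate of 80 nM and a range from 30 nM to 220 nM in this assay.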

Compound 4, half-maximal inhibitory concentration: 269 nM
Compound 4: middle estimate off by 3.4-fold (0.53 log units), on the low side, outside the stated range (above it).
By their numbers in this assay, from the lowest: compound 3; then compound 4; then compound 1; then compound 2.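

Cyano in place of methoxy gives a 3.5-fold higher number from compound 3 to compound 4 (0.54 log units; beyond the scatter) in this assay and so shows that this place, para to a large group, responds to what it carries, even though the two groups match in their counts of heavy atoms and hydrogen-bond acceptors. Of these two groups, methoxy gives the lower number. No measurement offered here accounts for the gap. Going by these compounds, whether an amine or a carboxylic acid at this place would fall below compound 3 stays open. So does whether this step would carry over to the phenyl or naphthalen-1-yl sulfonyl compounds.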